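The compounds below may be only part of what the source reports. "The series", "measured", "known", "first", "only" and "open" are said of these compounds alone.

Measured so far:
compound 1 `C#CCSc1nc(Sc2nccs2)c(C#N)c(-c2ccc(C)cc2)n1`: 2450 nM
compound 2 `C=CC(=O)Nc1ccccc1CN(C(=O)Nc1cccc(C(F)(F)F)c1)C1CCN(C(C)CCC)CC1`: 16200 nM
compound 3 `C#CCSc1nc(Sc2nncs2)c(C#N)c(-c2cc(OC)c(OC)c(OC)c2)n1`: 4660 nM

These numbers come from a functional assay on SMMC-7721 cells (Homo sapiens) for antiproliferative activity, read by MTT assay, with a stated time of 72 h; a lower number here means a stronger inhibitor, a higher number a weaker inhibitor. Compound 3 stands second highest of the three: its number lies within the scatter of that of compound 1, so the two cannot be told apart, and beyond the scatter below that of compound 2, which is the weaker inhibitor. Compound 4 `C#CCSc1nc(Sc2nc(C)cs2)c(C#N)c(-c2cc(OC)c(OC)c(OC)c2)n1` has not been measured. It differs from compound 3 in one place: 4-methyl-1,3-thiazol-2-yl in place of 1,3,4-thiadiazol-2-yl on a sulfur. For the measured compounds named here, no measured pair differs by this swap alone, so its effect is not known here. Compound 1 carries a ring of the same kind and sits within the scatter of compound 3, which points to a small step. The expected step is a 1.3-fold lower number from compound 3 to compound 4 (0.12 log units; within the scatter), none beyond the scatter. Compound 4 is thus estimated at 3500 nM, in the range 1200 nM to 10000 nM.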

Compound 4, half-maximal inhibitory concentration: > 20000 nM
Compound 4 gave a limit, no number (the forecaster's own chance of this, stated with the estimate: 5%); middle value at least 5.7-fold (0.75 log units) away from the limit.
By their numbers in this assay, from the lowest: compounds 1 and 3 (each within the scatter of the next); then compound 2. At a limit, above all of these: compound 4.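

Placing 4-methyl-1,3-thiazol-2-yl instead of 1,3,4-thiadiazol-2-yl on this sulfur gives an at least 4.2-fold higher number from compound 3 to compound 4 (0.63 log units; beyond the scatter) in this assay, so the group at this position can change the result beyond the scatter. The swap replaces one ring with another and adds a methyl, and that is enough to lose activity here. Compound 4 gives a limit and not a number, so the full size of the step stays unknown: the limit of > 20000 nM in this assay, at which 1 of the 4 values shown sits.

Whether the ring swap or the methyl accounts for the step remains open. So does the outcome of placing an amine or a carboxylic acid on this ring.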